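Changing one aryl group on a strong growth inhibitor

A few compounds are considered here, and "the series" means these few. Any claim that something is new, unique, unknown or untested is made for them only; others in the source may bear on it.

- compound 1 `CN(C)C(=O)c1cc2cnc(Nc3ccc(NC(=O)C4(C(=O)Nc5cccc(Cl)c5)CC4)cc3)nc2n1C1CCCC1`: 92.6%
- compound 2 `Nc1ccc(NC(=O)C2(C(=O)Nc3ccc(F)cc3)CC2)cc1F`: 30.4%

In a functional assay on T47D cells (Homo sapiens) for inhibition, read by CCK-8 assay, with a stated time of 72 h, tested at 10 uM (on this read-out higher numbers stand for more inhibition of growth at the one concentration tested and lower numbers for less inhibition of growth), compound 1 stands highest of the two measured compounds, and its value lies beyond the scatter from that of compound 2. Compound 3 `CN(C)C(=O)c1cc2cnc(Nc3ccc(NC(=O)C4(C(=O)Nc5ccc(C(F)(F)F)cc5)CC4)cc3)nc2n1C1CCCC1` keeps the rest of compound 1 but carries 4-(trifluoromethyl)phenyl in place of 3-chlorophenyl on an amide-type nitrogen. Within the data shown here, no measured pair shows this kind of swap, so the expectation is only tentative. The estimated a number 7.6 percentage points lower from compound 1 to compound 3 (within the scatter) is a small fall, possibly none beyond the scatter. For compound 3, the expected value is 85%, with an estimated range from 62% to 98%.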

Compound 3, percent growth inhibition at one concentration: 94.9%
Compound 3: the middle estimate sits 9.9 percentage points below what was measured; measured number inside the range.
By their numbers in this assay, from the lowest: compound 2; then compounds 1 and 3 (each within the scatter of the next).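

On the amide-type nitrogen, 4-(trifluoromethyl)phenyl in place of 3-chlorophenyl gives a number 2.3 percentage points higher from compound 1 to compound 3 (within the scatter) in this assay, so the two compounds cannot be told apart on this read-out. This one swap of aryl group therefore costs no growth inhibition beyond the scatter. No available measurement explains why the two groups read alike. Still open, from the compounds shown here alone, is whether a plain phenyl, a pyridine or a cyclohexyl group on the same nitrogen would read the same. A single tested concentration also leaves open whether compound 1 and compound 3 would separate at lower concentrations.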